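The source may hold more compounds than are shown below. What is called first, only, known or untested is meant among the compounds shown, and "the series" means these compounds.

Measured so far, in a functional assay on the whole organism with Rattus norvegicus as the target, at a dose of 20 mg/kg by the oral route; on this read-out lower numbers stand for less inhibition and higher numbers for more inhibition at the one dose given (going by the name of the read-out):

compound 1 `O=C(/C=C1\CCc2ccc(F)cc21)NCC1CC1` gives 21%
compound 2 `CNC(=O)/C=C1\CCc2ccc(Cl)cc21` gives 25%

Compound 1 has the smaller of the two numbers, yet the gap to compound 2 lies within the usual scatter of this kind of measurement, so the two cannot be told apart on this read-out alone. Both show only modest inhibition at the dose given.

Compound 3 `O=C(/C=C1\CCc2ccc(F)cc21)N1CCC1` has not been measured. It differs from compound 1 in one place: azetidin-1-yl in place of (cyclopropylmethyl)amino on a carbonyl carbon. Among the measured compounds shown here, no pair of measured compounds shows what such a change does on this read-out, so there is nothing to lean on beyond the modest value of compound 1 itself.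

For compound 3 the step is expected to be small, a number 1 percentage points lower from compound 1 to compound 3 (within the scatter), likely not beyond the scatter in either direction. Compound 3 is therefore estimated at 20%, with a range from 5% to 40%.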

Compound 3, a percentage reported as inhibition, in the whole organism at one dose (the size of the read-out at that dose, not a potency): 0%
Compound 3: middle estimate off by 20 percentage points, on the high side; measured number outside the range, below it.
By their numbers in this assay, from the lowest: compound 3; then compounds 1 and 2 (each within the scatter of the next).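

The group on the carbonyl carbon turns out to matter in this assay: with the core of compound 1 kept, azetidin-1-yl in place of (cyclopropylmethyl)amino gives a number 21 percentage points lower from compound 1 to compound 3 (beyond the scatter). The change removes the amide hydrogen, the one hydrogen-bond donor counted in the group that leaves, and it also replaces an open link to a three-membered carbon ring with a four-membered ring that holds the nitrogen. No measurement at hand says why the number falls.

The compounds shown cannot separate the loss of the amide hydrogen from the change of ring; dimethylamino on the same carbonyl carbon, with no amide hydrogen and no ring, would bear on that. From the compounds shown here alone, it also remains open whether a larger ring such as piperidin-1-yl would behave like azetidin-1-yl.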